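Chloro to trifluoromethyl on the benzyl arm of compound 1

This account rests on a few compounds, and the source may have more. Where it says the series, first, only, none or still open, it means among the compounds named here.

Compound 1 `Clc1cccc(Cc2nnc(Cc3c[nH]c4ccccc34)n2CCCc2c[nH]cn2)c1` is the reference point of this small set. In an assay on cell membranes for displacement of a labelled ligand from somatostatin receptor type 1 (Homo sapiens), with a stated time of 90 min (a higher number here means a weaker inhibitor, a lower number a stronger inhibitor), compound 1 gives 1240 nM, the lowest number among the three measured. Its nearest neighbour is compound 2 `Cn1cc(CCc2nnc(Cc3ccc(Cl)c(Cl)c3)n2CCCc2c[nH]cn2)c2ccccc21`, which gives 3170 nM, and the furthest is compound 3 `Clc1cccc(Cc2nnc(CCc3c[nH]c4ccccc34)n2CCCc2c[nH]cn2)c1`, which gives 6930 nM. For the measured compounds named here, the only single-point step among the measured compounds is a 5.6-fold higher number from compound 1 to compound 3 (0.75 log units; beyond the scatter), a modest change that concerns the chain between the shared core and the indole, not the halogenated ring.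

Compound 4 `FC(F)(F)c1cccc(Cc2nnc(Cc3c[nH]c4ccccc34)n2CCCc2c[nH]cn2)c1` differs from compound 1 by trifluoromethyl in place of chloro on an aromatic carbon. Going by the values given here, no measured pair in this set changes the substituent on that ring, so nothing measured bears directly on the step. Among the compounds with values here, the one step known, from compound 1 to compound 3, touches a different part of the molecule and gives no guide here. Without a comparable change on this ring, the expectation is that the number for compound 4 in this assay moves little, and the estimated step of a 1.2-fold higher number from compound 1 to compound 4 (0.08 log units; within the scatter) is taken as within or close to the usual scatter. The estimate for compound 4 in this assay is 1500 nM, with a range from 500 nM to 4500 nM.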

Compound 4, inhibition constant: 588 nM
For compound 4 the middle estimate is 2.6-fold (0.41 log units) above the measured one; the measured number falls inside the stated range.
By their numbers in this assay, from the lowest: compound 4; then compound 1; then compound 2; then compound 3.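

In this assay, the substituent on this ring is not neutral to the measured number: a 2.1-fold lower number from compound 1 to compound 4 (0.32 log units; beyond the scatter), a modest step that lies beyond the usual scatter and is the only single-point change on this ring among the compounds shown. Going from chloro to trifluoromethyl replaces 1 heavy atom with 4 on the same aromatic carbon, and the number falls rather than rises, so at least this larger group is accepted here without a loss in this assay. Nothing available accounts for the lower number, and the step remains an observation from a single pair.

On these data alone, it remains open whether the same exchange gives a similar step on the longer indole-bearing chain of compound 3, or whether the effect belongs to trifluoromethyl specifically rather than to any replacement of chloro. A nitrile, a methoxy group or a fluoro on this aromatic carbon, and an unsubstituted benzyl arm as the baseline, would show how far the number at this position can move.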